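Removing the para chloro from compound 3

This account rests on a few compounds, and the source may have more. Where it says the series, first, only, none or still open, it means among the compounds named here.

Three compounds share one core and differ only in the aryl group on it. Compound 1 `Cn1c(-c2cccc(Cl)c2)nc2c(NC3CCCC3)ncnc21` gives 6.5 nM in an assay on CHO cells for displacement of a labelled ligand from adenosine receptor A1 (Homo sapiens), read by scintillation counting, with a stated time of 3 h; a higher number here means a weaker inhibitor, a lower number a stronger inhibitor. Compound 2 `COc1ccc(-c2nc3c(NC4CCCC4)ncnc3n2C)cc1` gives 75 nM, and compound 3 `Cn1c(-c2ccc(Cl)cc2)nc2c(NC3CCCC3)ncnc21` gives 18 nM. Compound 3 therefore stands second highest of the three numbers: the step of a 2.8-fold higher number from compound 1 to compound 3 (0.44 log units; beyond the scatter) and the step of a 4.2-fold lower number from compound 2 to compound 3 (0.62 log units; beyond the scatter) place it between the other two. Compound 4 `Cn1c(-c2ccccc2)nc2c(NC3CCCC3)ncnc21` is compound 3 with hydrogen in place of chloro on an aromatic carbon.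

Within the data shown here, no measured step strips a substituent off this ring entirely, so the guidance is indirect. The step of a 4.2-fold lower number from compound 2 to compound 3 (0.62 log units; beyond the scatter) shows that the identity of the group at this position matters by a modest amount, and the step of a 12-fold higher number from compound 1 to compound 2 (1.06 log units; beyond the scatter) shows that swapping the aryl group can shift the number by a large amount. Taking away the chloro is expected to cost some of what the chloro provides, so a modest rise in the number, meaning weaker binding, is expected for compound 4, about a 1.9-fold higher number from compound 3 to compound 4 (0.29 log units; within the scatter). Compound 4 is estimated at 35 nM in this assay, with a likely range from 12 nM to 100 nM.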

Compound 4, inhibition constant: 2.8 nM
Estimate against measurement, compound 4: 13-fold (1.10 log units) above; measured number below the stated range.
By their numbers in this assay, from the lowest: compound 4; then compound 1; then compound 3; then compound 2.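

In this assay the unsubstituted phenyl ring gives the lowest number of the four compounds, and the chloro of compound 3 turns out to be a cost rather than a gain: a 6.4-fold lower number from compound 3 to compound 4 (0.81 log units; beyond the scatter). The other two substituents show the same direction, with a 27-fold lower number from compound 2 to compound 4 (1.43 log units; beyond the scatter) for the methoxy and a 2.3-fold lower number from compound 1 to compound 4 (0.37 log units; beyond the scatter) for the chloro of compound 1. None of the three groups shown improves on plain hydrogen, so on the shared core this ring needs no substituent to reach the strongest binding seen here, and the price of a substituent varies with the group and its place, from the modest step for the chloro of compound 1 to the large step for the methoxy.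

No measurement shown here explains why hydrogen does better than these groups. On these data alone, it remains open whether any other group on this ring, such as fluoro, an amine or a carboxylic acid, would match or beat compound 4, or whether the higher numbers seen with chloro and methoxy extend to them as well.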